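A Single Chloro Added to the Benzoyl Ring

A few compounds are considered here, and "the series" means these few. Any claim that something is new, unique, unknown or untested is made for them only; others in the source may bear on it.

Compound 1 `O=C(Nc1ccc(Cl)c(-c2nnc3c(Cl)cccn23)c1)c1ccccc1`: > 100000 nM
Compound 2 `O=C(Nc1ccc(Cl)c(-c2nnc3c(Cl)cccn23)c1)c1c(F)cccc1Cl`: > 100000 nM

Compound 1 and compound 2 share one core and differ only in the ring carried on the carbonyl carbon. In a functional assay on MCF7 cells (Homo sapiens) for antiproliferative activity, read by MTT assay, with a stated time of 72 h (a lower number here means a stronger inhibitor, a higher number a weaker inhibitor), compound 1 gives > 100000 nM, which is a limit of the assay and not a number. Compound 2 gives > 100000 nM in this assay, again only a limit. Among the compounds with values here, the one measured step, a step that the two limits leave unreadable from compound 1 to compound 2, cannot be sized because both ends rest at the limit of > 100000 nM in this assay, at which 2 of the 2 values shown sit.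

Compound 3 `O=C(Nc1ccc(Cl)c(-c2nnc3c(Cl)cccn23)c1)c1ccccc1Cl` has not yet been measured. It differs from compound 1 by chloro in place of hydrogen on an aromatic carbon, and that chloro also forms part of the change leading from compound 1 to compound 2. With both measured neighbours resting at the limit, the step of a number no higher from compound 1 to compound 3 (the limit leaves the size open) is expected to show no move beyond the scatter. Compound 3 is therefore expected to give 100000 nM in this assay, most likely again reported only as a limit, within 30000 nM to 300000 nM.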

Compound 3, half-maximal inhibitory concentration: 92200 nM
The estimate for compound 3 lay 1.1-fold (0.04 log units) above the measured number; low and high end bracket the measured number.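

In this assay, within the data shown here, compound 3, with its 2-chlorophenyl, gives the first reading in this set that is a number and not a limit, so this position now has a foothold on the scale. The data give an at least 1.0-fold lower number from compound 1 to compound 3 (0.03 log units; that floor lies within the scatter) and an at least 1.0-fold lower number from compound 2 to compound 3 (0.03 log units; that floor lies within the scatter). Each of these is only a floor, so chloro in place of hydrogen is not shown to do more than the scatter allows, and the true size of both steps stays open: the limit of > 100000 nM in this assay, at which 2 of the 3 values shown sit.

The compounds shown leave open how an amine or a carboxylic acid in place of this chloro would read, and whether a longer chain there would bring the number far lower. They also leave open how far the true values of compound 1 and compound 2 lie from that of compound 3.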